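The source may hold more compounds than are shown below. What is called first, only, known or untested is meant among the compounds shown, and "the series" means these compounds.

The measured compounds:
compound 1 `C[C@H](Nc1ncnc2[nH]cnc12)c1nn(-c2ccncc2)c2cc(F)ccc12`, 5%
compound 2 `C[C@H](Nc1ncnc2[nH]cnc12)c1nn(-c2cccc(S(C)(=O)=O)c2)c2cc(F)ccc12`, 11%

In a functional assay on Hep 3B2 cells (Homo sapiens) for inhibition, read by sulforhodamine B assay, with a stated time of 72 h, tested at 10 uM (on this read-out higher numbers stand for more inhibition at the one concentration tested (going by the name of the read-out) and lower numbers for less inhibition), compound 2 gives 11%, and in this assay compound 1 gives 5%. Compound 2 thus stands alongside compound 1 on the numbers shown, since a number 6 percentage points higher from compound 1 to compound 2 (within the scatter) is within the scatter; that step concerns only the substituent on the aromatic nitrogen.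

Compound 3 `C[C@H](Nc1nc(N)nc(N)c1C#N)c1nn(-c2cccc(S(C)(=O)=O)c2)c2cc(F)ccc12` is not yet measured. It differs from compound 2 at a different place: a group of 10 heavy atoms (5 carbon, 5 nitrogen; one six-membered aromatic ring with 2 hetero atoms) in place of a group of 9 heavy atoms (5 carbon, 4 nitrogen; one five-membered aromatic ring with 2 hetero atoms, one six-membered aromatic ring with 2 hetero atoms), on an amine nitrogen. For the measured compounds named here, no measured step touches the group on the amine nitrogen, so the one step in hand, a number 6 percentage points higher from compound 1 to compound 2 (within the scatter), gives no guide to this change. Going by the values given here, the only anchor is the value of compound 2, which is 11%. Compound 3 is therefore expected to give about 10%, with a range from 0% to 30%, which means an expected step of a number 1 percentage points lower from compound 2 to compound 3 (within the scatter) and no change beyond the scatter.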

Compound 3, a percentage reported as inhibition, at one concentration (the size of the read-out at that concentration, not a potency): 36%
The estimate for compound 3 lay 26 percentage points below the measured number; the whole stated range lies below it.
By their numbers in this assay, from the lowest: compounds 1 and 2 (each within the scatter of the next); then compound 3.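

Changing the group on the amine nitrogen has a visible effect in this assay: placing 2,6-diamino-5-cyanopyrimidin-4-yl there gives a number 25 percentage points higher from compound 2 to compound 3 (beyond the scatter). This is the first step shown to lie beyond the scatter, unlike the change on the aromatic nitrogen, which gave a number 6 percentage points higher from compound 1 to compound 2 (within the scatter). The new group differs from the old in its ring count, its nitrile and its hydrogen-bond donor and acceptor counts, and nothing available explains the rise.

As far as these compounds go, it remains open which part of the 2,6-diamino-5-cyanopyrimidin-4-yl group goes with the step, for instance whether a carboxamide or a chlorine in place of the nitrile would keep it. From the compounds shown here alone, it is also open whether the step would hold with pyridin-4-yl on the aromatic nitrogen.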